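This account rests on a few compounds, and the source may have more. Where it says the series, first, only, none or still open, it means among the compounds named here.

Measured so far in a functional assay on SK-OV-3 cells (Homo sapiens) for antiproliferative activity, read by MTT assay, with a stated time of 24 h; a lower number here means a stronger inhibitor, a higher number a weaker inhibitor:
- compound 1 `COc1ccc(C(=O)/C=C/c2cc(OC)c(OC)c(OC)c2)c2c1C=CC(C)(C)O2`: 9700 nM
- compound 2 `COc1ccc(C(=O)/C=C/c2ccc(F)cc2)c2c1C=CC(C)(C)O2`: > 10000 nM
- compound 3 `COc1ccc(C(=O)/C=C/c2ccc(N(c3ccccc3)c3ccccc3)cc2)c2c1C=CC(C)(C)O2`: > 10000 nM

Compound 2 has no numerical value in this assay. Compound 2 stands at > 10000 nM, which is a limit of the assay. Compound 3 stands at > 10000 nM, which is also a limit. Only compound 1 has a measured number, 9700 nM. The series therefore offers little resolution so far, with the limit of > 10000 nM in this assay, at which 2 of the 3 values shown sit, describing most of the data.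

The next compound is compound 4 `COc1ccc(C(=O)/C=C/c2ccc(N3CCCC3)cc2)c2c1C=CC(C)(C)O2`, which has pyrrolidin-1-yl in place of fluoro on an aromatic carbon of a six-membered aromatic ring of carbon only, para to a large group: pyrrolidin-1-yl in place of fluoro on an aromatic carbon. Among the measured compounds shown here, no step between measured compounds is available to calibrate this change. The expectation rests on compound 3, whose substituent also contains nitrogen and which still reads > 10000 nM, again a limit. The estimated step of an at least 1.1-fold lower number from compound 2 to compound 4 (0.04 log units; that floor lies within the scatter) is expected to stay within the scatter, with no firm direction. A limit rather than a number is also a likely result for compound 4. Compound 4 is estimated at 9000 nM, with an expected range of 3000 nM to 20000 nM.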

Compound 4, half-maximal inhibitory concentration: 7370 nM
Compound 4: the middle estimate sits 1.2-fold (0.09 log units) above what was measured; low and high end bracket the measured number.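

In this assay, among the compounds shown here, pyrrolidin-1-yl in place of fluoro on an aromatic carbon, para to a large group, gives the first step that can be read at this position, though only as a floor and not as a size (an at least 1.3-fold lower number from compound 2 to compound 4 (0.13 log units; that floor lies within the scatter)). Compound 4 reads 7370 nM and thereby gives a number, not a limit, at this place, so compound 2 and compound 4 cannot be said to differ beyond the scatter, yet a larger gap is not excluded. Compound 3, whose substituent at the same place also contains nitrogen, stays at > 10000 nM and that is a limit, so nitrogen on this carbon does not by itself bring a number, and the series remains thinly resolved: the limit of > 10000 nM in this assay, at which 2 of the 4 values shown sit.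

From the compounds shown here alone, whether piperidin-1-yl, morpholin-4-yl or dimethylamino at this carbon would give a number clearly beyond the scatter from compound 4 remains open. Also open, going by these compounds, is how a carboxylic acid or a hydroxyl group would read here, and whether the pyrrolidin-1-yl ring itself or only its linking nitrogen carries the reading.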